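Trifluoromethoxy on the core of compound 1

The source may report more compounds than this note shows. Statements on the series, on what has been measured and on what is new or still open speak of the compounds shown alone.

Values in a functional assay on COLO 205 cells (Homo sapiens) for inhibition, read by sulforhodamine B assay (on this read-out higher numbers stand for weaker inhibition of growth and lower numbers for stronger inhibition of growth), so far are these
compound 1 `c1ccc(-c2ccc(-c3ccc(-c4nc5ccccc5[nH]4)cc3)cc2)cc1` (100000 nM)
compound 2 `COc1cc(-c2ccc(-c3ccc(-c4nc5cc(C)ccc5[nH]4)cc3)cc2)cc(OC)c1OC` (190 nM)

Compound 1 stands at the higher of the two numbers, on the side of weaker inhibition of growth, and compound 2 lies lower by a margin well beyond the scatter. Among the compounds with values here, compound 3 `FC(F)(F)Oc1ccc(-c2ccc(-c3ccc(-c4nc5ccccc5[nH]4)cc3)cc2)cc1` keeps the core of compound 1 and carries trifluoromethoxy in place of hydrogen on an aromatic carbon, para to a large group trifluoromethoxy in place of hydrogen on an aromatic carbon as the only change. Within the data shown here, no measured pair differing in one place is available, so the size of this step rests on thin evidence. A move to a lower number in this assay is expected, probably beyond the scatter but modest, since compound 2 (190 nM) shows that much lower numbers occur in this series while nothing ties them to this group. The expected change is a 10-fold lower number from compound 1 to compound 3 (1.00 log units; beyond the scatter) in this estimate, with wide uncertainty. Compound 3 is estimated at 10000 nM with an expected range from 1500 nM to 100000 nM on this read-out.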

Compound 3, concentration for 50% growth inhibition: 100000 nM
Compound 3: the middle estimate sits 10-fold (1.00 log units) below what was measured, within the range that was stated.
By their numbers in this assay, from the lowest: compound 2; then compounds 1 and 3 (each within the scatter of the next).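

In this assay the series now has its first step that can be read at a single place: trifluoromethoxy in place of hydrogen on an aromatic carbon, para to a large group, gives no change at the digits printed from compound 1 to compound 3 (within the scatter) on the core of compound 1. At this position, then, this one change on its own does not bring the read-out towards stronger inhibition of growth, and compound 3 stays with compound 1 at the weak end of the values seen so far. Nothing on hand gives a reason for this outcome.

Within the data shown here, whether an amine, a carboxylic acid or a longer alkoxy chain at this same position would move the number remains open, since trifluoromethoxy is the only group read here and one group cannot speak for the position as a whole. Going by these compounds, compound 2 at 190 nM differs from compound 1 in more than one place, so its value cannot yet be assigned to any one of its groups, and it remains open which of them, alone or together, goes with that number.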